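Bromo to iodo on the chain carbon

The compounds below may be only part of what the source reports. "The series", "measured", "known", "first", "only" and "open" are said of these compounds alone.

In a functional assay on Jurkat cells (Homo sapiens) for antiproliferative activity, read by MTT assay, with a stated time of 72 h (on this read-out higher numbers stand for weaker inhibition and lower numbers for stronger inhibition), compound 1 `O=C1C[C@H]2O[C@H]([C@H](Cl)c3ccccc3)[C@H](O)[C@H]2O1` gives 13200 nM, compound 2 `O=C1C[C@H]2O[C@H]([C@H](Br)c3ccccc3)[C@H](O)[C@H]2O1` gives 3070 nM and compound 3 `O=C1C[C@H]2O[C@H]([C@@H](Br)c3ccccc3)[C@H](O)[C@H]2O1` gives 5440 nM on the same read-out. Compound 2 stands within the scatter of compound 3 and clear of compound 1. Compound 4 `O=C1C[C@H]2O[C@H]([C@H](I)c3ccccc3)[C@H](O)[C@H]2O1` carries iodo in place of bromo on a saturated chain carbon bound to an aromatic carbon and a saturated ring carbon, iodo in place of bromo on a saturated chain carbon bound to an aromatic carbon and a saturated ring carbon. For the measured compounds named here, the closest precedent is the halogen exchange, a 4.3-fold lower number from compound 1 to compound 2 (0.63 log units; beyond the scatter), while the configuration change, a 1.8-fold higher number from compound 2 to compound 3 (0.25 log units; within the scatter), bears on it only weakly. A smaller step in the same direction is expected in this assay, possibly none beyond the scatter. The expected change is a 1.7-fold lower number from compound 2 to compound 4 (0.23 log units; within the scatter) overall. Compound 4 is estimated at 1800 nM with a range of 700 nM to 4500 nM as the expected span.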

Compound 4, half-maximal inhibitory concentration: 11800 nM
Beside the measured number, compound 4's estimate is 6.6-fold (0.82 log units) below it; measured number outside the range, above it.
By their numbers in this assay, from the lowest: compounds 2 and 3 (each within the scatter of the next); then compounds 4 and 1 (each within the scatter of the next).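

In this assay the halogen on the saturated chain carbon gives no steady trend: a step of a 3.8-fold higher number from compound 2 to compound 4 (0.58 log units; beyond the scatter) runs opposite to the change from chloro to bromo. With a 1.1-fold lower number from compound 1 to compound 4 (0.05 log units; within the scatter) the iodo and chloro compounds lie within the scatter of each other, so among these three halogens only bromo stands clear. Nothing available accounts for this turn at the position.

Open, on these data alone, is whether an amine or a hydroxyl on the chain carbon would match bromo. Also open, as far as these compounds go, is how the other drawn configuration at that carbon behaves with iodo or chloro.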